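Removing the Ring Carbamate from Compound 3

The source may hold more compounds than are shown below. What is called first, only, known or untested is meant among the compounds shown, and "the series" means these compounds.

Compound 3 `CC(C)(C)OC(=O)N1C[C@@H](n2cc(-c3ccc4nc(N)sc4n3)nn2)C[C@H]1C(=O)Nc1ccc(Cl)cc1Cl` gives 28.3% in a functional assay on K562/Adr cells (Homo sapiens) for inhibition, read by MTT assay, with a stated time of 48 h, tested at 30 uM (on this read-out higher numbers stand for more inhibition at the one concentration tested (going by the name of the read-out) and lower numbers for less inhibition), the second highest of three numbers. Its nearest neighbour is compound 2 `CC(C)(C)OC(=O)N1C[C@@H](n2cc(-c3ccc4nc(N)sc4n3)nn2)C[C@H]1C(=O)Nc1ccc(Cl)c(C(F)(F)F)c1` with 27.4%, and the step of a number 0.9 percentage points higher from compound 2 to compound 3 (within the scatter) lies within the scatter. Compound 1 `Nc1n[nH]c2cc(-c3cn([C@@H]4CN[C@H](C(=O)Nc5ccc(Cl)cc5Cl)C4)nn3)ccc12`, which also bears the (2,4-dichlorophenyl)carbamoyl group and a hydrogen on an amine nitrogen in a ring, gives 29.4% in this assay. Compound 4 `Nc1nc2ccc(-c3cn([C@@H]4CN[C@H](C(=O)Nc5ccc(Cl)cc5Cl)C4)nn3)nc2s1` differs from compound 3 by hydrogen in place of tert-butoxycarbonyl on an amine nitrogen in a ring. Among the compounds with values here, no measured step in this assay touches this position; the one measured step concerns only the amide aryl group. Since compound 1 and compound 3 sit at the same level, compound 4 is expected to stay within the scatter, with a number 0.7 percentage points higher from compound 3 to compound 4 (within the scatter). Compound 4 is therefore estimated at 29%, between 18% and 40%.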

Compound 4, a percentage reported as inhibition, at one concentration (the size of the read-out at that concentration, not a potency): 42.2%
Compound 4: middle estimate off by 13.2 percentage points, on the low side; measured number above the stated range.
By their numbers in this assay, from the lowest: compounds 2, 3 and 1 (each within the scatter of the next); then compound 4.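

Hydrogen in place of tert-butoxycarbonyl on the amine nitrogen in the ring gives a number 13.9 percentage points higher from compound 3 to compound 4 (beyond the scatter) in this assay, so this position, untouched by the earlier step, does affect the read-out. With hydrogen on that nitrogen in both compounds, exchanging the group of 10 heavy atoms on an aromatic carbon gives a number 12.8 percentage points higher from compound 1 to compound 4 (beyond the scatter), so the gain at this nitrogen depends on which group sits there. Nothing measured here explains either step.

The compounds shown leave open whether a methyl or acetyl group on this nitrogen would hold the level of compound 4 or whether only hydrogen does.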